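The source may report more compounds than this note shows. Statements on the series, on what has been measured and on what is new or still open speak of the compounds shown alone.

Measured compounds: compound 1 `CCCC[C@H](CO)Nc1nc(N)nc2cccnc12`, compound 2 `CCCC[C@H](CCO)Nc1nc(N)nc2cccnc12`, compound 3 `CCCC[C@@H](Nc1nc(N)nc2cccnc12)C(=O)O`.

In an assay on tissue (PBMC cells) for agonist activity at Toll-like receptor 8 (Homo sapiens), with a stated time of 24 h (on this read-out lower numbers stand for an effect already at smaller amounts and higher numbers for an effect only at larger amounts of compound), compound 1 gives 790 nM. Compound 2 gives 4300 nM in this assay. For compound 3 this assay reports only a limit, > 50000 nM, which is the limit of > 50000 nM in this assay, at which 1 of the 3 values shown sits. Compound 3 therefore stands at the weak end of the three: the steps of an at least 63-fold higher number from compound 1 to compound 3 (1.80 log units; beyond the scatter) and an at least 11-fold higher number from compound 2 to compound 3 (1.06 log units; beyond the scatter) are both large.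

Compound 4 `CCCC[C@@H](Nc1nc(N)nc2cccnc12)C(N)=O` differs from compound 3 by amino in place of hydroxy on a carbonyl carbon. Among the measured compounds shown here, no measured step covers this change itself; the only steps that bear on it are the two leading into compound 3, both large losses on arrival at the carboxy. Replacing the carboxy with a carbamoyl is expected to recover part of that loss, so the estimated step of an at least 2.5-fold lower number from compound 3 to compound 4 (0.39 log units; beyond the scatter) is downward, though a further limit remains possible. Compound 4 is expected at 20000 nM, within 3000 nM to 100000 nM.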

Compound 4, half-maximal effective concentration: 36000 nM
Estimate against measurement, compound 4: 1.8-fold (0.26 log units) below; the measured number falls inside the stated range.
By their numbers in this assay, from the lowest: compound 1; then compound 2; then compound 4. At a limit, above all of these: compound 3.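

Compound 3 carries only a limit, so the change from carboxy to carbamoyl cannot be read as a gain or a loss in this assay: the limit of > 50000 nM in this assay, at which 1 of the 4 values shown sits.

All that can be given for this change is an at least 1.3-fold lower number from compound 3 to compound 4 (0.14 log units; that floor lies within the scatter).

The carbamoyl group can be read against the two hydroxyl-bearing groups, and it falls short of both: against 2-hydroxyethyl the step is modest, with an 8.4-fold higher number from compound 2 to compound 4 (0.92 log units; beyond the scatter), and against hydroxymethyl it is large, with a 46-fold higher number from compound 1 to compound 4 (1.66 log units; beyond the scatter). At this saturated chain carbon, both carbonyl-bearing groups shown therefore go with weaker numbers than hydroxymethyl and 2-hydroxyethyl.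

From the compounds shown here alone, how an aminomethyl group or a methyl ester would fall at this carbon stays open. So does the effect of a longer chain on the same carbon.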